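Iodo for bromo on the sugar ring of compound 2

A few compounds are considered here, and "the series" means these few. Any claim that something is new, unique, unknown or untested is made for them only; others in the source may bear on it.

Within the data shown here, compound 2 `Nc1ccn(C2OC(CO)C(Br)C2O)c(=O)n1` shows the lowest of the three numbers so far in a functional assay on P815 cells (Mus musculus) for antiproliferative activity (on this read-out higher numbers stand for weaker inhibition and lower numbers for stronger inhibition), at 0.05 ug/mL. Among the measured compounds shown here, compound 1 `Nc1nc(=O)n(C2OC(CO)C(I)C2O)cc1F` gives 0.1 ug/mL in this assay, a number that sits within the usual scatter of the one for compound 2. Compound 3 `Nc1nc(=O)n(C2OC(CO)C(Br)C2O)cc1F` gives 0.2 ug/mL, and the step of a 4.0-fold higher number from compound 2 to compound 3 (0.60 log units; beyond the scatter) is the only one among these three that lies beyond the scatter. Compound 4 `Nc1ccn(C2OC(CO)C(I)C2O)c(=O)n1` has not yet been measured; it differs from compound 2 by iodo in place of bromo on a saturated ring carbon. For the measured compounds named here, one measured step bears directly on this exchange, running in the opposite direction: a 2.0-fold higher number from compound 1 to compound 3 (0.30 log units; within the scatter), which stays within the scatter. Reading that step backwards, an estimated step of a 1.4-fold lower number from compound 2 to compound 4 (0.15 log units; within the scatter) is expected, toward a somewhat lower number, though of a size that need not exceed the scatter. Compound 4 is therefore expected to give 0.035 ug/mL in this assay, with a range from 0.012 ug/mL to 0.1 ug/mL.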

Compound 4, concentration for 50% inhibition: 0.3 ug/mL
Estimate against measurement, compound 4: 8.6-fold (0.93 log units) below, outside the stated range (above it).
By their numbers in this assay, from the lowest: compounds 2, 1, 3 and 4 (each within the scatter of the next, the first and the last beyond it).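

In this assay, iodo in place of bromo on a saturated ring carbon gives a 6.0-fold higher number from compound 2 to compound 4 (0.78 log units; beyond the scatter), so this position is sensitive to the exchange when the aromatic carbon carries hydrogen. The pair with fluoro did not show this, and the effect of the exchange depends on the core: the same change on two cores in this assay, a 2.0-fold higher number (0.30 log units; within the scatter) from compound 1 to compound 3 and a 6.0-fold lower number (0.78 log units; beyond the scatter) from compound 4 to compound 2, 12-fold (1.08 log units) apart, beyond the scatter of two such steps

The aromatic substituent is likewise tied to the group on the saturated ring carbon, since with iodo in place, hydrogen in place of fluoro gives a 3.0-fold higher number from compound 1 to compound 4 (0.48 log units; beyond the scatter), whereas with bromo in place the same change runs the other way: the same change on two cores in this assay, a 4.0-fold higher number (0.60 log units; beyond the scatter) from compound 2 to compound 3 and a 3.0-fold lower number (0.48 log units; beyond the scatter) from compound 4 to compound 1, 12-fold (1.08 log units) apart, beyond the scatter of two such steps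

On these data alone, whether a chloro, an azido or an amine at this position would follow bromo or iodo remains open. These four compounds also cannot say why the two exchanges depend on each other, or whether that dependence extends beyond this set.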